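This account rests on a few compounds, and the source may have more. Where it says the series, first, only, none or still open, it means among the compounds named here.

Working notes on the series in a functional assay on HCT-116 cells (Homo sapiens) for antiproliferative activity, read by MTT assay, with a stated time of 24 h; a lower number here means a stronger inhibitor, a higher number a weaker inhibitor: compound 1 `COc1cc(OC)c(-c2coc3cc(OCc4ccccc4)ccc3c2=O)cc1OC` gives 2280 nM, compound 2 `COc1cc(OC)c(-c2coc3cc(OCc4ccc(Br)cc4)ccc3c2=O)cc1OC` gives 1980 nM and compound 3 `COc1cc(OC)c(-c2coc3cc(OCc4ccc(C#N)cc4)ccc3c2=O)cc1OC` gives 4220 nM. Compound 3 stands level with compound 1 within the scatter, a 1.9-fold higher number from compound 1 to compound 3 (0.27 log units; within the scatter), and modestly apart from compound 2, a 2.1-fold higher number from compound 2 to compound 3 (0.33 log units; beyond the scatter). Next comes compound 4 `COc1cc(OC)c(-c2coc3cc(OCc4ccccc4Br)ccc3c2=O)cc1OC`, with this change: 2-bromophenyl in place of 4-cyanophenyl on a saturated chain carbon bound to an oxygen on an aromatic ring. Among the measured compounds shown here, no measured compound carries 2-bromophenyl, so the evidence is indirect. The nearest step is a 2.1-fold higher number from compound 2 to compound 3 (0.33 log units; beyond the scatter), which read in reverse points to a lower number, while a 1.2-fold lower number from compound 1 to compound 2 (0.06 log units; within the scatter) shows bromo in place of hydrogen staying within the scatter. The expected step in this assay is small: a 1.8-fold lower number from compound 3 to compound 4 (0.26 log units; within the scatter). Compound 4 is estimated at 2300 nM, with an expected range of 1100 nM to 4800 nM.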

Compound 4, half-maximal inhibitory concentration: 4550 nM
Compound 4: the middle estimate sits 2.0-fold (0.30 log units) below what was measured; the measured number falls inside the stated range.
By their numbers in this assay, from the lowest: compounds 2, 1, 3 and 4 (each within the scatter of the next, the first and the last beyond it).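

In this assay, 2-bromophenyl in place of 4-bromophenyl gives a 2.3-fold higher number from compound 2 to compound 4 (0.36 log units; beyond the scatter) as a modest step, the first sign that the place of the bromo on this ring can count. Against the unsubstituted phenyl the 2-bromo compound stays within the scatter at a 2.0-fold higher number from compound 1 to compound 4 (0.30 log units; within the scatter) and it stands level with the nitrile at a 1.1-fold higher number from compound 3 to compound 4 (0.03 log units; within the scatter) in the same assay. No measurement on hand accounts for these steps. Still open, from the compounds shown here alone, is whether an amine or a carboxylic acid on this ring, or a longer chain in place of the saturated chain carbon, would move the number further.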